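This account rests on a few compounds, and the source may have more. Where it says the series, first, only, none or still open, it means among the compounds named here.

Working notes on the series in a functional assay on A549 cells (Homo sapiens) for inhibition, read by sulforhodamine B assay, with a stated time of 48 h, tested at 100 uM; a higher number here means more inhibition of growth at the concentration tested, a lower number less inhibition of growth. Compound 1 `Cc1ccc2occ(C3N=C(c4ccccc4)SS3)c(=O)c2c1` gives 67%. Compound 2 `O=c1c(C2N=C(c3ccccc3)SS2)coc2ccc(Cl)cc12` gives 73%. Compound 3 `O=c1c(C2N=C(c3ccccc3)SS2)coc2cc(Cl)c(Cl)cc12` gives 52%. For the measured compounds named here, compound 2 stands at the top of the three numbers, but the step of a number 6 percentage points higher from compound 1 to compound 2 (within the scatter) is within the scatter, so compound 1 and compound 2 are not separated; only the step of a number 21 percentage points lower from compound 2 to compound 3 (beyond the scatter) is beyond it.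

Compound 4 `O=c1c(C2N=C(c3ccccc3)SS2)coc2ccc(F)cc12` is not yet measured. It differs from compound 2 by fluoro in place of chloro on an aromatic carbon. The step that bears on this change is a number 6 percentage points higher from compound 1 to compound 2 (within the scatter), a swap of one group for another on the same aromatic carbon, which left the number within the scatter. The step of a number 21 percentage points lower from compound 2 to compound 3 (beyond the scatter) concerns a group entering at a different carbon and does not speak to this exchange. On that basis no step beyond the scatter is expected in this assay for the change from compound 2 to compound 4, and the expected shift is a number 8 percentage points lower from compound 2 to compound 4 (within the scatter). Compound 4 is therefore estimated at 65%, with a range of 50% to 78%.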

Compound 4, percent growth inhibition at one concentration: 55%
Compound 4: middle estimate off by 10 percentage points, on the high side; the range from low to high includes it.
By their numbers in this assay, from the lowest: compounds 3 and 4 (each within the scatter of the next); then compounds 1 and 2 (each within the scatter of the next).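

In this assay this aromatic carbon proves sensitive to the group it carries: a number 18 percentage points lower from compound 2 to compound 4 (beyond the scatter) and a number 12 percentage points lower from compound 1 to compound 4 (beyond the scatter), whereas the earlier exchange at the same carbon, a number 6 percentage points higher from compound 1 to compound 2 (within the scatter), did not separate its two compounds. Fluoro is therefore set apart from both chloro and methyl, and the exchange of one heavy atom for one heavy atom, with no change in hydrogen-bond donors, acceptors or net charge, is enough for a step beyond the scatter. Nothing shown here gives a reason for this difference.

Going by these compounds, whether a methoxy group, an amine or a carboxylic acid on this carbon would fall with fluoro or with chloro and methyl remains open. Also open, on these data alone, is whether the fluoro result carries over to a core that bears the second chloro of compound 3.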